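A few compounds are considered here, and "the series" means these few. Any claim that something is new, unique, unknown or untested is made for them only; others in the source may bear on it.

Compound 1 `Cc1c(OCCCCOc2ccc(C(=O)O)c(Cl)c2)ccc(C(=O)CC(C)C)c1O` belongs to a small set in which a common core is joined through a four-carbon chain to a benzoic acid. In an assay on HEK293 cells for positive allosteric modulation of metabotropic glutamate receptor 2 (Rattus norvegicus), read by thallium flux, with a stated time of 2.5 min (a higher number here means that more compound is needed for the effect, a lower number that less compound is needed), compound 1 gives 151 nM. Among the compounds with values here, its companion compound 2 `Cc1c(OCCCCOc2ccc(C(=O)O)cc2Cl)ccc(C(=O)CC(C)C)c1O` gives 96 nM in this assay, and the only step measured between them, a 1.6-fold lower number from compound 1 to compound 2 (0.20 log units; within the scatter), keeps the two values within the scatter of each other, so neither can be placed ahead of the other. A third member, compound 3 `COC(=O)c1ccc(OCCCCOc2ccc(C(=O)CC(C)C)c(O)c2C)cc1`, has no number in this assay: "not determined" (no result reported).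

Compound 4 `Cc1c(OCCCCOc2ccc(C(=O)O)c(Cl)c2)ccc(C(=O)CC(C)C)c1C` is compound 1 altered in a single place: methyl in place of hydroxy on an aromatic carbon. Within the data shown here, the one measured step, from compound 1 to compound 2, concerns the chlorine position on the benzoic acid and not the hydroxy group on the core, so nothing measured here bears directly on this change. In the absence of any comparison of this kind the direction cannot be read from the data, and the expectation for compound 4 rests on the change alone. Compound 4 is therefore estimated at 400 nM in this assay, with a wide range from 100 nM to 2000 nM, which amounts to an expected step of a 2.6-fold higher number from compound 1 to compound 4 (0.42 log units; beyond the scatter).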

Compound 4, half-maximal effective concentration: > 10000 nM
Compound 4: no number, only a limit; the forecaster's own chance of this, stated with the estimate: 15%; middle value at least 25-fold (1.39 log units) from the limit.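

In this assay, putting methyl in place of hydroxy on this aromatic carbon, ortho to a methyl group and ortho to an isobutylcarbonyl group, gives an at least 66-fold higher number from compound 1 to compound 4 (1.82 log units; beyond the scatter). Within the data shown here, for compound 4 the result is a limit of the assay and not a number: the limit of > 10000 nM in this assay, at which 1 of the 4 values shown sits. The earlier step, a 1.6-fold lower number from compound 1 to compound 2 (0.20 log units; within the scatter), moved only the chlorine on the benzoic acid and stayed within the scatter, whereas this single exchange on the core lies beyond it, and so the series now shows for the first time that the group at this position can decide whether compound 1 keeps a measurable value at all.

On these data alone, one exchange cannot separate the loss of the hydroxy from the arrival of the methyl, so it stays open how a methoxy group, an amine or a plain hydrogen at this place would read. Also open, as far as these compounds go, is whether the same exchange would have a comparable outcome on compound 2, with its chlorine in the other position on the benzoic acid.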